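Methoxy Addition in a Series of Amide Antiproliferatives

The compounds below may be only part of what the source reports. "The series", "measured", "known", "first", "only" and "open" are said of these compounds alone.

Of the compounds shown here, three have been measured in a functional assay on SK-BR-3 cells (Homo sapiens) for antiproliferative activity; on this read-out higher numbers stand for weaker inhibition and lower numbers for stronger inhibition. Compound 1 `COc1cc(Cc2ccc3cc(NC(=O)c4ccc(O)c(CC=C(C)C)c4)c(=O)oc3c2C)ccc1O` gives 10700 nM, compound 2 `CC(C)=CCc1cc(C(=O)Nc2cc3ccc(Cc4ccc(O)cc4)c(C)c3oc2=O)ccc1O` gives 21500 nM, and compound 3 `COc1cccc(-c2cc(C(=O)Nc3cc4ccc(Cc5ccccc5)c(C)c4oc3=O)ccc2OC)c1` gives 4090 nM, the lowest number of the three, its gaps to compound 1 and compound 2 both lying beyond the scatter. Compound 2 and compound 1 differ by methoxy in place of hydrogen on an aromatic carbon, which brought a 2.0-fold lower number from compound 2 to compound 1 (0.30 log units; within the scatter). The difference between the cores of compound 2 and compound 3 is not broken down here. Compound 4 `COc1ccc(Cc2ccc3cc(NC(=O)c4ccc(OC)c(-c5cccc(OC)c5)c4)c(=O)oc3c2C)cc1` has not yet been measured; it differs from compound 3 by methoxy in place of hydrogen on an aromatic carbon. This is the same kind of change as that between compound 2 and compound 1, not the same one: there the methoxy sat ortho to a hydroxy group and meta to a large group, here it sits para to a large group. Resting on a 2.0-fold lower number from compound 2 to compound 1 (0.30 log units; within the scatter), only a small step is expected, a 1.4-fold lower number from compound 3 to compound 4 (0.13 log units; within the scatter). Compound 4 is therefore estimated at 3000 nM, expected to fall between 1200 nM and 9000 nM.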

Compound 4, half-maximal inhibitory concentration: > 100000 nM
Compound 4 was reported as a limit; the forecaster's own chance of this, stated with the estimate: 3%; middle value at least 33-fold (1.52 log units) from the limit.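

In this assay, methoxy in place of hydrogen on an aromatic carbon brought an at least 24-fold higher number from compound 3 to compound 4 (1.38 log units; beyond the scatter), and the step seen on the other core did not carry over to this one: the same change on two cores in this assay, a 2.0-fold lower number (0.30 log units; within the scatter) from compound 2 to compound 1 and an at least 24-fold higher number (1.38 log units; beyond the scatter) from compound 3 to compound 4, at least 49-fold (1.69 log units) apart, beyond the scatter of two such steps. Going by these compounds, compound 4 gives > 100000 nM, which is a limit of the assay and not a number, and the full size of the step stays unknown: the limit of > 100000 nM in this assay, at which 1 of the 4 values shown sits. The two cores also differ in what surrounds the methoxy, and the two steps do not show which difference matters or give any cause for the gap.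

The compounds shown leave open whether an ethoxy group, a fluorine or an amine in the same place would stay near compound 3. They also leave open whether the methoxy of compound 4 would give a similar step on any further core.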